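The source may report more compounds than this note shows. Statements on the series, on what has been measured and on what is new or still open speak of the compounds shown alone.

The series shares a fused two-ring core. Compound 1 `O=C1c2sc(C#Cc3ccccc3)nc2CN1C1CC1` carries a lactam in that core, and in an assay on HEK293 cells for negative allosteric modulation of metabotropic glutamate receptor 5 (Homo sapiens), read by FLIPR, with a stated time of 1 h (a lower number here means a stronger inhibitor, a higher number a weaker inhibitor), compound 1 gives 23 nM. Compound 2 `CN1CCc2nc(C#Cc3ccccc3)sc2C1` instead carries a methyl on the amine nitrogen in the ring. In this assay compound 2 reaches only the limit of the assay, > 10000 nM, which is not a number. Compound 3 `CN1CCc2nc(C#Cc3cccc(F)c3)sc2C1` adds fluoro on an aromatic carbon. In this assay compound 3 likewise sits at the limit, > 10000 nM. The step that the two limits leave unreadable from compound 2 to compound 3 cannot be read because both ends sit at the limit of > 10000 nM in this assay, at which 2 of the 3 values shown sit.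

Compound 4 `C(#Cc1nc2c(s1)CN(C1CCCCC1)CC2)c1ccccc1` differs from compound 2 by cyclohexyl in place of methyl on an amine nitrogen in a ring. No measured step touches the amine nitrogen, so nothing shown bears directly on this change; the only measured step, from compound 2 to compound 3, is unreadable. Compound 1 with 23 nM shows that a related core can give a strong inhibitor, but it says nothing about the substituent on the amine. The change from compound 2 to compound 4 is therefore expected to leave the value near the limit, with a number no higher from compound 2 to compound 4 (the limit leaves the size open) as the estimated step. Compound 4 is expected at 10000 nM in this assay, between 2000 nM and 50000 nM, with a fair chance that again only a limit is reported.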

Compound 4, half-maximal inhibitory concentration: > 10000 nM
Compound 4 was reported as a limit; the forecaster's own chance of this, stated with the estimate: 65%; the middle value sits exactly at the limit.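

Compound 2 and compound 4 both sit at a limit of the assay rather than at a number, so the change from methyl to cyclohexyl cannot be read: the limit of > 10000 nM in this assay, at which 3 of the 4 values shown sit.

The compounds shown leave open whether any group on the amine nitrogen in the ring gives a readable value in this assay.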